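A Bromophenyl in Place of a Dimethoxyphenyl

The source may hold more compounds than are shown below. What is called first, only, known or untested is meant among the compounds shown, and "the series" means these compounds.

Of the compounds shown here, two sharing one core have been measured in a functional assay on A549 cells (Homo sapiens) for cytotoxicity, read by MTT assay, with a stated time of 72 h; a lower number here means a stronger inhibitor, a higher number a weaker inhibitor. Compound 1, `COc1ccc(/C=C/C(=O)Nc2cc3c(Nc4ccc(F)c(Cl)c4)ncnc3cc2O[C@H]2CCOC2)c(OC)c1`, gives 9350 nM in this assay, the lower of the two numbers. Compound 2, `COc1cc2ncnc(Nc3ccc(F)c(Cl)c3)c2cc1NC(=O)/C=C/c1ccccc1[N+](=O)[O-]`, gives 33300 nM, a higher number that lies beyond the usual scatter when set against compound 1. The two differ in more than one place, so no single structural step can be read from them.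

Compound 3, `O=C(/C=C/c1ccc(Br)cc1)Nc1cc2c(Nc3ccc(F)c(Cl)c3)ncnc2cc1O[C@H]1CCOC1`, has not yet been measured in this assay. It differs from compound 1 in one place: 4-bromophenyl in place of 2,4-dimethoxyphenyl on a double-bonded chain carbon bound to a double-bonded chain carbon. For the measured compounds named here, nothing measured so far shows what this swap does, so any expectation rests on compound 1 alone, with no matched pair to lean on. The expected step is a 1.3-fold higher number from compound 1 to compound 3 (0.11 log units; within the scatter), small, within the scatter or drifting a little toward a higher number. Compound 3 is therefore estimated to give about 12000 nM in this assay. The range for that estimate runs from 4000 nM to 36000 nM.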

Compound 3, half-maximal inhibitory concentration: 35300 nM
For compound 3 the middle estimate is 2.9-fold (0.47 log units) below the measured one, within the range that was stated.
By their numbers in this assay, from the lowest: compound 1; then compounds 2 and 3 (each within the scatter of the next).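

For the compounds shown here, this pair gives the first clean reading of this position, on a double-bonded chain carbon bound to a double-bonded chain carbon, since the two compounds differ only there. In this assay, 4-bromophenyl in place of 2,4-dimethoxyphenyl gives a 3.8-fold higher number from compound 1 to compound 3 (0.58 log units; beyond the scatter), so the group at this place does matter for the number, and this swap moves it toward a weaker inhibitor. Nothing available bears on what lies behind the step, and a single pair cannot say which part of the swap accounts for it.

The swap removes the oxygen-bearing methoxy groups and brings in a bromine atom in one move, so the effect of losing the former cannot be separated from the effect of gaining the latter. Also open, on these data alone, is where a plain phenyl ring or a pyridine ring at this place would fall relative to these two groups, and whether an amine on the ring, such as a dimethylamino group, would bring the number down or push it up.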